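The compounds below may be only part of what the source reports. "The series", "measured", "known", "first", "only" and "open" are said of these compounds alone.

Working notes on the series in a functional assay on MDA-MB-231 cells (Homo sapiens) for cytotoxicity, read by MTT assay, with a stated time of 72 h; a lower number here means a stronger inhibitor, a higher number a weaker inhibitor. Compound 3 `CCN(CC)Cc1ccc2nc(NC(=O)N/N=C/c3c[nH]c4ccccc34)sc2c1` gives 1900 nM, within the scatter of the other two: compound 1 `CCN(CC)Cc1ccc2nc(NC(=O)N/N=C/c3cn(Cc4ccc(C(C)(C)C)cc4)c4ccccc34)sc2c1` gives 2120 nM and compound 2 `CCN(CC)Cc1ccc2nc(NC(=O)N/N=C/c3cn(Cc4ccc(Cl)cc4)c4ccccc34)sc2c1` gives 2570 nM. Compound 4 `CCN(CC)Cc1ccc2nc(NC(=O)N/N=C/c3cn(Cc4ccccc4)c4ccccc34)sc2c1` differs from compound 3 by benzyl in place of hydrogen on an aromatic nitrogen. Within the data shown here, two measured steps bear on this, each replacing a substituted benzyl on that nitrogen with hydrogen: a 1.1-fold lower number from compound 1 to compound 3 (0.05 log units; within the scatter) and a 1.4-fold lower number from compound 2 to compound 3 (0.13 log units; within the scatter). The change on the benzyl ring, a 1.2-fold higher number from compound 1 to compound 2 (0.08 log units; within the scatter), is small as well. No step beyond the scatter is therefore expected, in either direction. The expected step is a 1.2-fold higher number from compound 3 to compound 4 (0.06 log units; within the scatter). The estimated value for compound 4 is 2200 nM, with an expected range of 1300 nM to 3600 nM.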

Compound 4, half-maximal inhibitory concentration: 1470 nM
Compound 4: middle estimate off by 1.5-fold (0.18 log units), on the high side, within the range that was stated.
By their numbers in this assay, from the lowest: compounds 4, 3, 1 and 2 (each within the scatter of the next).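

In this assay, the plain benzyl on the aromatic nitrogen stays within the scatter of hydrogen (a 1.3-fold lower number from compound 3 to compound 4 (0.11 log units; within the scatter)), as the substituted benzyls did. Removing the group on the benzyl ring also stays within the scatter, both for tert-butyl (a 1.4-fold lower number from compound 1 to compound 4 (0.16 log units; within the scatter)) and for chloro (a 1.7-fold lower number from compound 2 to compound 4 (0.24 log units; within the scatter)), so this position has so far tolerated every change shown without a step beyond the scatter. No measurement at hand explains this result. Still open, on these data alone, is whether an amine or a carboxylic acid on the benzyl ring, or a longer chain in place of benzyl, would give a step beyond the scatter.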